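Cyclobutylmethyl in place of propyl on the aryl ether oxygen

The source may hold more compounds than are shown below. What is called first, only, known or untested is meant among the compounds shown, and "the series" means these compounds.

Compound 3 `CCCOc1cccc2ccc(N)nc12` gives 1100 nM in an assay on cells with melanin-concentrating hormone receptor 1 (Homo sapiens) as the target, read by radioligand binding (on this read-out higher numbers stand for weaker inhibition and lower numbers for stronger inhibition), the highest of the two numbers recorded here. Compound 1 `CCCC(C)Oc1cccc2ccc(N)nc12` gives 105 nM in this assay. Compound 2 `CCOCCOc1cccc2ccc(N)nc12` reaches only the limit of > 2000 nM in this assay, not a number. The change to compound 4 `Nc1ccc2cccc(OCC3CCC3)c2n1` is cyclobutyl in place of ethyl on a saturated chain carbon bound to an oxygen on an aromatic ring. Within the data shown here, two measured steps bear on it: a 10-fold higher number from compound 1 to compound 3 (1.02 log units; beyond the scatter), and an at least 19-fold higher number from compound 1 to compound 2 (1.27 log units; beyond the scatter); the third, an at least 1.8-fold lower number from compound 2 to compound 3 (0.25 log units; that floor lies within the scatter), lies within the scatter. Cyclobutylmethyl stands closer to 1-methylbutyl than to 2-ethoxyethyl in the words of the change, so for compound 4 a lower number than compound 3 is expected, a 3.7-fold lower number from compound 3 to compound 4 (0.56 log units; beyond the scatter), smaller than the step back to compound 1. Compound 4 is therefore estimated at 300 nM, between 100 nM and 900 nM.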

Compound 4, half-maximal inhibitory concentration: 432 nM
Compound 4: the middle estimate sits 1.4-fold (0.16 log units) below what was measured; the range from low to high includes it.
By their numbers in this assay, from the lowest: compound 1; then compound 4; then compound 3. At a limit, above all of these: compound 2.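

On the saturated chain carbon bound to an oxygen on an aromatic ring, cyclobutyl in place of ethyl gives a 2.5-fold lower number from compound 3 to compound 4 (0.41 log units; beyond the scatter), so a carbon-only ring is accepted here and the number falls. Cyclobutylmethyl does not match the branched 1-methylbutyl, with a 4.1-fold higher number from compound 1 to compound 4 (0.61 log units; beyond the scatter). The step from 2-ethoxyethyl rests on a limit of the assay and is only a floor: an at least 4.6-fold lower number from compound 2 to compound 4 (0.66 log units; beyond the scatter).

Open, from the compounds shown here alone, is whether the ring itself or only the added carbon count carries the gain over propyl. Isobutyl and cyclopentylmethyl at this oxygen would help separate the two.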